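This account rests on a few compounds, and the source may have more. Where it says the series, first, only, none or still open, it means among the compounds named here.

The measured compounds:
Compound 1 `C1=C(CS/C(=N\C2CCCCCC2)NC2CCCCCC2)N2CCN=C2S1` gives 3.1 nM in a functional assay on CCRF-CEM cells for inhibition of C-X-C chemokine receptor type 4 (Homo sapiens), read by calcium flux; a lower number here means a stronger inhibitor, a higher number a weaker inhibitor.
Compound 2 `C1=C(CS/C(=N\C2CCCCC2)NC2CCCCCC2)N2CCN=C2S1` gives 6.6 nM in this assay.
Compound 3 `CC(C)(C)C1CCC(N/C(=N/C2CCCCC2)SCC2=CSC3=NCCN23)CC1` gives 437 nM in this assay.

Compound 2 holds the second highest of the three numbers. For the measured compounds named here, the one step that joins it to a neighbour is a 2.1-fold higher number from compound 1 to compound 2 (0.33 log units; beyond the scatter), where cyclohexyl replaces cycloheptyl on the double-bonded nitrogen. Going by the values given here, compound 3, at 437 nM, lies far above compound 2, at 6.6 nM; no single-point step connects these two.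

Compound 4 `C1=C(CS/C(=N\C2CCCCC2)Nc2ccccc2)N2CCN=C2S1` is not yet measured. Its change from compound 2 is phenyl in place of cycloheptyl on an amine nitrogen. Among the compounds with values here, only one measured step touches the ring groups on the two nitrogens, the step from compound 1 to compound 2, and that step swaps one saturated ring for another on the other nitrogen; no measured step puts an aromatic ring on the amine nitrogen. That step was modest, so a modest to moderate rise in the number is the most that the data support, with wide uncertainty. Compound 4 is therefore expected to give about 25 nM, estimated between 6 nM and 120 nM. The expected step is a 3.8-fold higher number from compound 2 to compound 4 (0.58 log units; beyond the scatter).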

Compound 4, half-maximal inhibitory concentration: 5280 nM
For compound 4 the middle estimate is 210-fold (2.32 log units) below the measured one; measured number outside the range, above it.
By their numbers in this assay, from the lowest: compound 1; then compound 2; then compound 3; then compound 4.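

In this assay, for the compounds shown here, the step of an 800-fold higher number from compound 2 to compound 4 (2.90 log units; beyond the scatter) shows that the amine nitrogen is a far more sensitive place than the earlier compounds could reveal: exchanging its saturated cycloheptyl for an aromatic phenyl takes compound 2 at 6.6 nM to compound 4 at 5280 nM. Going by these compounds alone, the only earlier step, a 2.1-fold higher number from compound 1 to compound 2 (0.33 log units; beyond the scatter), exchanged one saturated ring for another on the double-bonded nitrogen and was modest, so the size of a change at one nitrogen does not carry over to a different change at the other. Nothing available bears on the reason for this large rise.

The change alters ring size and aromatic character together, and the compounds shown do not separate the two. Also open, on these data alone, is how a benzyl group or a pyridyl ring would read on the amine nitrogen.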